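A few compounds are considered here, and "the series" means these few. Any claim that something is new, unique, unknown or untested is made for them only; others in the source may bear on it.

In a functional assay on MRC5 cells (Homo sapiens) for inhibition, read by microscopy and resazurin assay, with a stated time of 72 h (on this read-out higher numbers stand for weaker inhibition and lower numbers for stronger inhibition), compound 1 `C=CCONC(=O)CN1C(=O)S/C(=C\c2ccc(C(=O)N[C@@H](CC(C)C)C(=O)OC)cc2)C1=O` is a limit of the assay and not a number, at > 128000 nM. Compound 2 `C=CCONC(=O)CN1C(=O)S/C(=C\c2ccc(C(=O)N[C@H](C(=O)OC)C(C)C)cc2)C1=O` is the same limit in this assay, at > 128000 nM. Compound 3 `C=CCONC(=O)Cn1cc(C(=O)NCC(=O)N[C@H](C(=O)O)C(C)C)c2ccccc21`, built on a different core, gives in this assay only a limit as well, at > 128000 nM. The change from compound 2 to compound 1 is isobutyl in place of isopropyl on a saturated chain carbon bound to an amide-type nitrogen and a carbonyl carbon, and the step it made, a step that the two limits leave unreadable from compound 2 to compound 1, cannot be read off because of the limit of > 128000 nM in this assay, at which 3 of the 3 values shown sit. How the core of compound 3 differs from the core of compound 2 is not broken down here.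

Compound 4 `C=CCONC(=O)Cn1cc(C(=O)NCC(=O)N[C@@H](CC(C)C)C(=O)O)c2ccccc21` has not been measured. Within the data shown here, it differs from compound 3 by isobutyl in place of isopropyl on a saturated chain carbon bound to an amide-type nitrogen and a carbonyl carbon, the same change as the one from compound 2 to compound 1, made at the same kind of place. Since the measured pair gives no readable step, the expectation for compound 4 rests on compound 3 sitting at its limit of > 128000 nM. The step from compound 3 to compound 4 in this assay is expected to be a step that the limit leaves unreadable from compound 3 to compound 4. For compound 4 in this assay an estimated value of 160000 nM, between 60000 nM and 450000 nM, is expected.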

Compound 4, half-maximal inhibitory concentration: > 128000 nM
Compound 4 gave a limit, no number (the forecaster's own chance of this, stated with the estimate: 85%); the middle value is on the limit's open side.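

No size can be given for the step from compound 3 to compound 4, since each of the two compounds gives a limit of the assay and not a number: the limit of > 128000 nM in this assay, at which 4 of the 4 values shown sit. The compounds shown leave open whether isobutyl in place of isopropyl makes any difference in this assay, and how the two cores compare there.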